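This account rests on a few compounds, and the source may have more. Where it says the series, first, only, none or still open, it means among the compounds named here.

Measured so far:
Compound 1 `C=C1[C@@H](O)[C@H](n2cnc3c(O)nc(N)nc32)O[C@@H]1CO`: > 200000 nM (a limit)
Compound 2 `C=C1[C@@H](O)[C@H](n2cnc3c(OC)nc(N)nc32)O[C@@H]1CO`: > 500000 nM (a limit)

Both compounds were tested in a functional assay on MT4 cells (Homo sapiens) for inhibition (on this read-out higher numbers stand for weaker inhibition and lower numbers for stronger inhibition), and neither returned a number. Compound 2 gives > 500000 nM, which is a limit of the assay. Compound 2 therefore stands only on (the limit of > 500000 nM in this assay, at which 1 of the 2 values shown sits). Compound 1 gives > 200000 nM, which is also a limit.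

Compound 3 `C=C1[C@@H](O)[C@H](n2cnc3c(S)nc(N)nc32)O[C@@H]1CO` carries sulfanyl in place of methoxy on an aromatic carbon, next to the ring nitrogen: sulfanyl in place of methoxy on an aromatic carbon.

Among the measured compounds shown here, only one measured step bears on this change. It is a step that the two limits leave unreadable from compound 1 to compound 2, with methyl in place of hydrogen on an oxygen on an aromatic ring. Since that step has no readable size, it supports no expectation of a particular size or direction in this assay. Compound 3 is expected to remain a very weak inhibitor, though this rests on thin evidence, and it may well return only a limit. The expected move is an at least 2.0-fold lower number from compound 2 to compound 3 (0.30 log units; that floor lies within the scatter). Compound 3 is estimated at 250000 nM, with an expected range from 40000 nM to 800000 nM.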

Compound 3, half-maximal inhibitory concentration: 12000 nM
Compound 3: the middle estimate sits 21-fold (1.32 log units) above what was measured; the whole stated range lies above it.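

In this assay, sulfanyl on this aromatic carbon, next to the ring nitrogen, gives the first readable number among the compounds shown: compound 3 gives 12000 nM. Hydroxy and methoxy at the same place returned only limits. Swapping methoxy for sulfanyl gives an at least 41-fold lower number from compound 2 to compound 3 (1.61 log units; beyond the scatter), and swapping hydroxy for sulfanyl gives an at least 16-fold lower number from compound 1 to compound 3 (1.22 log units; beyond the scatter), so this one carbon substituent can move the read-out by a large margin on an otherwise unchanged core. The step between compound 1 and compound 2 cannot be read, so the large change is tied to sulfanyl alone and says nothing about any order between hydroxy and methoxy.

Going by these compounds, the full size of the step away from methoxy stays open because compound 2 stands only on a limit: the limit of > 500000 nM in this assay, at which 1 of the 3 values shown sits. Also open is whether an amine or a methylsulfanyl group on this aromatic carbon would keep a number close to that of compound 3, which would show whether the sulfur alone or the sulfanyl hydrogen goes with the change.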